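Hydrogen in place of bromo on compound 3

This account rests on a few compounds, and the source may have more. Where it says the series, first, only, none or still open, it means among the compounds named here.

In a functional assay on T47D cells (Homo sapiens) for inhibition, read by CCK-8 assay, with a stated time of 72 h, tested at 10 uM (on this read-out higher numbers stand for more inhibition of growth at the one concentration tested and lower numbers for less inhibition of growth), compound 1 (`CN(C)C(=O)c1cc2cnc(Nc3ccc(NC(=O)C4(C(=O)Nc5ccccc5F)CC4)cc3)nc2n1C1CCCC1`) gives 97.8%, compound 2 (`CN(C)C(=O)c1cc2cnc(Nc3ccc(NC(=O)C4(C(=O)Nc5cccc(Cl)c5)CC4)cc3)nc2n1C1CCCC1`) gives 92.6% and compound 3 (`CN(C)C(=O)c1cc2cnc(Nc3ccc(NC(=O)C4(C(=O)Nc5cccc(Br)c5)CC4)cc3)nc2n1C1CCCC1`) gives 94.6%. Compound 3 thus stands within the scatter of both others. Compound 4 (`CN(C)C(=O)c1cc2cnc(Nc3ccc(NC(=O)C4(C(=O)Nc5ccccc5)CC4)cc3)nc2n1C1CCCC1`) carries hydrogen in place of bromo on an aromatic carbon. The closest measured change is the exchange of chloro for bromo, a number 2 percentage points higher from compound 2 to compound 3 (within the scatter). The exchanges of aryl groups are a number 5.2 percentage points lower from compound 1 to compound 2 (within the scatter) and a number 3.2 percentage points lower from compound 1 to compound 3 (within the scatter). For the measured compounds named here, no measured pair shows the removal of a halogen, so this evidence is indirect. No step beyond the scatter is expected. The expected step is a number 1.6 percentage points lower from compound 3 to compound 4 (within the scatter). For compound 4 the estimate is 93%, with an expected range from 82% to 100%.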

Compound 4, percent growth inhibition at one concentration: 93.9%
Estimate against measurement, compound 4: 0.9 percentage points below; measured number inside the range.
By their numbers in this assay, from the lowest: compounds 2, 4, 3 and 1 (each within the scatter of the next).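

In this assay the 3-bromophenyl group gives way to phenyl with a number 0.7 percentage points lower from compound 3 to compound 4 (within the scatter) and the 3-chlorophenyl group with a number 1.3 percentage points higher from compound 2 to compound 4 (within the scatter) while the 2-fluorophenyl group gives way to phenyl with a number 3.9 percentage points lower from compound 1 to compound 4 (within the scatter) in the same way. Across these four compounds, a halogen on this ring is therefore not required for growth inhibition at the one concentration tested, which the exchanges of one halogen for another could not show. Nothing measured here explains this lack of a step beyond the scatter. All four values lie close together at a single concentration, so any differences in potency remain unresolved. As far as these compounds go, whether an amine, a carboxylic acid or a methoxy group on this ring would keep this level of inhibition also remains open.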